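The source may report more compounds than this note shows. Statements on the series, on what has been measured and on what is new or still open speak of the compounds shown alone.

Of the compounds shown here, two built on a shared core have so far been tested in a functional assay on PC-3 cells (Homo sapiens) for antiproliferative activity, read by MTT assay, with a stated time of 12 h; a higher number here means a weaker inhibitor, a lower number a stronger inhibitor. Compound 1 has the structure `COc1cc(OC)c2c(=O)cc(/C=C/c3ccccc3)oc2c1`. In this assay compound 1 gives > 40000 nM, which is a limit of the assay and not a number. Compound 2, `COc1cc(OC)c2c(=O)cc(/C=C/c3ccc(C(F)(F)F)cc3)oc2c1`, differs from compound 1 by a trifluoromethyl in place of hydrogen on an aromatic carbon. In this assay compound 2 gives > 40000 nM, again a limit rather than a number. The step that the two limits leave unreadable from compound 1 to compound 2 therefore cannot be read, since both of its ends sit at the limit (the limit of > 40000 nM in this assay, at which 2 of the 2 values shown sit). Compound 3, `COc1cc(OC)c2c(=O)cc(/C=C/c3ccc(OC(F)(F)F)cc3)oc2c1`, has not yet been measured in this assay. It differs from compound 2 in a single place: trifluoromethoxy in place of trifluoromethyl on an aromatic carbon. Going by the values given here, no measured step tells what this exchange does, and the one step that exists, from compound 1 to compound 2, is unreadable. The step expected is a step that the limit leaves unreadable from compound 2 to compound 3, with no direction that can be claimed beyond the scatter. Compound 3 is estimated at 60000 nM in this assay, within a range from 20000 nM to 200000 nM, and most likely it too will be reported only as a limit.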

Compound 3, half-maximal inhibitory concentration: > 40000 nM
Compound 3 was reported as a limit (the forecaster's own chance of this, stated with the estimate: 75%); the middle value lies beyond the limit too.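

Compound 3 also sits at a limit of the assay and not at a number, so none of the steps among compound 1, compound 2 and compound 3 can be read: the limit of > 40000 nM in this assay, at which 3 of the 3 values shown sit. The compounds shown leave open how hydrogen, trifluoromethyl and trifluoromethoxy compare with one another in this assay.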